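The source may report more compounds than this note shows. Statements on the series, on what has been measured and on what is new or still open speak of the compounds shown alone.

Working notes on the series in an assay on isolated protein for inhibition of aldehyde dehydrogenase 1A1 (Homo sapiens), read by spectrophotometry, tested at 10 uM; a higher number here means more inhibition at the concentration tested (going by the name of the read-out), a lower number less inhibition. Compound 1 `CC(C)=CCn1c(CN2CCN(C(=O)C3CC3)CC2)nc2ccccc21` gives 74.3% and stands highest of the three measured numbers. Compound 2 `Cc1cccc(Cn2c(CN3CCN(C(=O)c4ccc(C(F)(F)F)cc4)CC3)nc3ccccc32)c1` gives 22.9%, and compound 3 `Cc1cccc(Cn2c(CN3CCN(C(=O)c4ccc(Cl)cc4)CC3)nc3ccccc32)c1` gives 23.2%; each lies beyond the scatter below compound 1, and the two of them are within the scatter of each other. Among the measured compounds shown here, the only one-place step between measured compounds is a number 0.3 percentage points higher from compound 2 to compound 3 (within the scatter), and it lies within the scatter.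

Compound 4 `O=C(C1CC1)N1CCN(Cc2nc3ccccc3n2Cc2ccccc2)CC1` is compound 1 with phenyl in place of 2-methylprop-1-en-1-yl on a saturated chain carbon bound to an aromatic nitrogen. For the measured compounds named here, no measured step touches this place: the one recorded step sits on the aromatic carbon at the other end of the molecule and is anyway within the scatter, so it gives no guidance here. Compounds 2 and 3 carry a benzyl-type group on the same saturated chain carbon, but they differ from compound 1 in more than one place, so their lower values cannot be assigned to this change alone. The expectation therefore rests on compound 1 itself, with wide uncertainty. For compound 4 the expected step is a number 19.3 percentage points lower from compound 1 to compound 4 (beyond the scatter), a modest drop that may or may not clear the scatter. Compound 4 is estimated at 55%, within 20% to 85%.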

Compound 4, a percentage reported as inhibition, at one concentration (the size of the read-out at that concentration, not a potency): 23.9%
Compound 4: middle estimate off by 31.1 percentage points, on the high side; the range from low to high includes it.
By their numbers in this assay, from the lowest: compounds 2, 3 and 4 (each within the scatter of the next); then compound 1.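

In this assay, among the compounds shown here, the step of a number 50.4 percentage points lower from compound 1 to compound 4 (beyond the scatter) is the first one-place change read at the saturated chain carbon bound to an aromatic nitrogen, and it is large. For the compounds shown here, this place therefore responds strongly to the group it carries, unlike the aromatic carbon of the only earlier step, a number 0.3 percentage points higher from compound 2 to compound 3 (within the scatter). The change replaces an open chain holding one double bond with one six-membered aromatic ring of carbon only and adds to the heavy-atom count of the group, and no supporting measurement bears on which of these differences accounts for the step.

The compounds shown leave open whether the high value of compound 1 depends on the double bond, on the branched open chain or simply on the absence of an aromatic ring, a question that saturated 3-methylbutyl and cyclohexylmethyl groups at this place would address. They also leave open whether 3-methylbut-2-en-1-yl gives a similar step when the cyclopropyl amide is replaced by the substituted benzoyl amides of compound 2 and compound 3.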